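Dropping the Methyl from the Core: Expected Potency

The source may report more compounds than this note shows. Statements on the series, on what has been measured and on what is new or still open speak of the compounds shown alone.

Compound 1 `Cc1ccc2[nH]c(=O)c(/C=N/c3ccc(O)cc3)cc2c1` gives 5240 nM in a functional assay, read by spectrophotometry, with a stated time of 3 min; a higher number here means a weaker inhibitor, a lower number a stronger inhibitor.
Compound 2 `Cc1ccc2[nH]c(=O)c(/C=N/c3ccccc3O)cc2c1` gives 8240 nM in this assay.
Compound 3 `Cc1ccc2[nH]c(=O)c(/C=N/CCO)cc2c1` gives 1190000 nM in this assay.

In this assay compound 2 holds the second highest of the three numbers. Its nearest neighbour is compound 1, since a 1.6-fold higher number from compound 1 to compound 2 (0.20 log units; within the scatter); its furthest is compound 3, since a 140-fold higher number from compound 2 to compound 3 (2.16 log units; beyond the scatter). Compound 4 `O=c1[nH]c2ccccc2cc1/C=N/c1ccccc1O` differs from compound 2 by hydrogen in place of methyl on an aromatic carbon. All measured steps concern only the group on the double-bonded nitrogen, so none of them bears on a change at the core. Among the measured compounds shown here, with no relevant step, compound 4 is expected to show no step beyond the scatter, a 1.0-fold lower number from compound 2 to compound 4 (0.00 log units; within the scatter). Compound 4 is therefore estimated at 8200 nM, ranging from 3000 nM to 22000 nM.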

Compound 4, half-maximal inhibitory concentration: 11700 nM
The estimate for compound 4 lay 1.4-fold (0.15 log units) below the measured number; the measured number falls inside the stated range.
By their numbers in this assay, from the lowest: compounds 1, 2 and 4 (each within the scatter of the next, the first and the last beyond it); then compound 3.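

Hydrogen in place of methyl on an aromatic carbon of the shared core gives a 1.4-fold higher number from compound 2 to compound 4 (0.15 log units; within the scatter) in this assay. Among the compounds shown here, this is the first step here at the core rather than on the double-bonded nitrogen, and with the 2-hydroxyphenyl group in place, the methyl can go without a change beyond the scatter. Nothing measured here explains this result.

From the compounds shown here alone, whether a methoxy group or a chlorine atom on that same carbon would shift the number remains open. So does whether losing the methyl would have the same outcome with the 4-hydroxyphenyl group of compound 1 or the 2-hydroxyethyl group of compound 3.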